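The compounds below may be only part of what the source reports. "The series", "measured", "known", "first", "only" and "open" are said of these compounds alone.

Values in an ADME assay on cells (Fibroblast, Homo sapiens) for inhibition, read by MTT assay, with a stated time of 24 h; a lower number here means a stronger inhibitor, a higher number a weaker inhibitor:
Compound 1 `Nc1ccc(C(=O)N/N=C/c2ccc3c(c2)no[n+]3[O-])cc1`: > 200000 nM
Compound 2 `CCCc1ccc(C(=O)N/N=C/c2ccc3c(c2)no[n+]3[O-])cc1`: > 200000 nM
Compound 3 `O=C(N/N=C/c1ccc2c(c1)no[n+]2[O-])c1ccc(Cl)cc1Cl`: 38300 nM

Compound 2 stands at > 200000 nM, which is a limit and not a number. Compound 1 also stands at a limit, > 200000 nM. Only compound 3 has a number, 38300 nM.

The next structure is compound 4 `CCCOc1ccc(C(=O)N/N=C/c2ccc3c(c2)no[n+]3[O-])cc1`, with propoxy in place of propyl on an aromatic carbon, para to a large group: propoxy in place of propyl on an aromatic carbon. Within the data shown here, the one measured step that touches compound 2, a step that the two limits leave unreadable from compound 1 to compound 2, gives no size to carry over. What remains is the limit of > 200000 nM in this assay, at which 2 of the 3 values shown sit. On that basis, no step beyond the scatter is expected in this assay, and neither direction can be favoured. The expected step is a number no higher from compound 2 to compound 4 (the limit leaves the size open). Compound 3 at 38300 nM shows that a number is possible among these compounds, so the expected range stays wide on the lower side. Compound 4 is estimated at 200000 nM, with an expected range of 70000 nM to 400000 nM.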

Compound 4, half-maximal inhibitory concentration: > 200000 nM
Compound 4 was reported as a limit; the forecaster's own chance of this, stated with the estimate: 70%; the middle value lies on the limit itself.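

Among these compounds, compound 1, compound 2 and compound 4 all stand at limits, so no step among them can be read: the limit of > 200000 nM in this assay, at which 3 of the 4 values shown sit.

Left open is how far apart these amino, propyl and propoxy compounds lie, and whether they differ at all.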